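Replacing 2-chlorophenyl with 4-methylphenyl on compound 3

The source may report more compounds than this note shows. Statements on the series, on what has been measured and on what is new or still open speak of the compounds shown alone.

Measured so far in an ADME assay on MT4 cells (Homo sapiens) for cytotoxicity, read by MTT assay, with a stated time of 96 h; on this read-out higher numbers stand for lower toxicity in this test and lower numbers for higher toxicity in this test
Compound 1 `Cc1ccc(C2CC(c3ccccc3)=NN2c2ccc(S(N)(=O)=O)cc2)cc1` gives 40000 nM
Compound 2 `NS(=O)(=O)c1ccc(N2N=C(c3ccc(OCc4ccccc4)cc3)CC2c2ccc(F)cc2)cc1` gives > 100000 nM as a limit of the assay and not a number
Compound 3 `NS(=O)(=O)c1ccc(N2N=C(c3ccc(OCc4ccccc4)cc3)CC2c2ccccc2Cl)cc1` gives 26000 nM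

For the measured compounds named here, compound 3 stands within the scatter of compound 1, the only other compound here with an exact number. Compound 4 `Cc1ccc(C2CC(c3ccc(OCc4ccccc4)cc3)=NN2c2ccc(S(N)(=O)=O)cc2)cc1` keeps the rest of compound 3 but carries 4-methylphenyl in place of 2-chlorophenyl on a saturated ring carbon of the shared core. Going by the values given here, the one measured step at this place is an at least 3.8-fold lower number from compound 2 to compound 3 (0.58 log units; beyond the scatter) and it lies beyond the scatter, so a change here can move the number. That step brought 2-chlorophenyl in and ended lower, which suggests that its removal may give some of this back. Compound 1 also carries 4-methylphenyl and gives 40000 nM on a core that differs elsewhere. Among the compounds with values here, no measured step brings 4-methylphenyl in, so the size remains uncertain. A small move to a higher number in this assay is expected, with an estimated size of a 1.6-fold higher number from compound 3 to compound 4 (0.21 log units; within the scatter) overall. Compound 4 is estimated at 42000 nM and expected to fall from 18000 nM to 100000 nM in four of five measurements.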

Compound 4, half-maximal cytotoxic concentration: 35000 nM
Compound 4: the middle estimate sits 1.2-fold (0.08 log units) above what was measured; the range from low to high includes it.
By their numbers in this assay, from the lowest: compounds 3, 4 and 1 (each within the scatter of the next). At a limit, above all of these: compound 2.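

In this assay, the swap at this saturated ring carbon gives a 1.3-fold higher number from compound 3 to compound 4 (0.13 log units; within the scatter), so 4-methylphenyl and 2-chlorophenyl cannot be told apart here, and adding benzyloxy on an aromatic carbon gives a 1.1-fold lower number from compound 1 to compound 4 (0.06 log units; within the scatter), which also shows no real shift. Methyl in place of fluoro, by contrast, gives an at least 2.8-fold lower number from compound 2 to compound 4 (0.45 log units; beyond the scatter), so among the three groups shown at this place only 4-fluorophenyl stands apart. Compound 2 sits at a limit of the assay and not a number, so the full size of that step stays unknown: the limit of > 100000 nM in this assay, at which 1 of the 4 values shown sits.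

What sets 4-fluorophenyl apart from the other two groups remains unexplained by these compounds. From the compounds shown here alone, it is also open whether a phenyl ring carrying an amine or a carboxylic acid at this place would move the number beyond the scatter.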